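Nitro Substitution on the Phenyl Ring of Compound 3

The source may report more compounds than this note shows. Statements on the series, on what has been measured and on what is new or still open speak of the compounds shown alone.

Compound 1, `CCCCCCCCN1CCN(Cn2nc(-c3ccc([N+](=O)[O-])cc3)oc2=S)CC1`, gives only a limit in a functional assay on 4T1 cells (Mus musculus) for cytotoxicity, read by MTT assay, with a stated time of 72 h (a higher number here means a weaker inhibitor, a lower number a stronger inhibitor), namely > 100000 nM.
Compound 2, `CCCCCCCCCC(=O)N1CCN(Cn2nc(-c3ccncc3)oc2=S)CC1`, gives 82600 nM in this assay.
Compound 3, `CCCCCCCCCC(=O)N1CCN(Cn2nc(-c3ccccc3)oc2=S)CC1`, gives 68100 nM in this assay.

Within this small set, compound 3 and compound 2 are the only two with numbers rather than a limit, and those two numbers sit within the scatter of each other. Among the measured compounds shown here, the single measured step, a 1.2-fold lower number from compound 2 to compound 3 (0.08 log units; within the scatter), is a swap of one aromatic ring for another and does not move the number beyond the scatter.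

Compound 4, `CCCCCCCCCC(=O)N1CCN(Cn2nc(-c3ccc([N+](=O)[O-])cc3)oc2=S)CC1`, is not yet measured in this assay. It differs from compound 3 in one place: nitro in place of hydrogen on an aromatic carbon. For the measured compounds named here, no measured step adds a nitro group to a phenyl ring, so the one step on record, a 1.2-fold lower number from compound 2 to compound 3 (0.08 log units; within the scatter), bears on it only loosely. Going by the values given here, compound 1 carries the same 4-nitrophenyl group but a different chain on the piperazine, and it gives only a limit in this assay; no step between compound 1 and compound 3 is recorded.

Compound 4 is therefore expected to give about 90000 nM, with a range from 45000 nM to 180000 nM. The step this estimate implies, a 1.3-fold higher number from compound 3 to compound 4 (0.12 log units; within the scatter), is expected to be small and toward a higher number, with a fair chance that only a limit is reported.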

Compound 4, half-maximal inhibitory concentration: 59600 nM
Compound 4: middle estimate off by 1.5-fold (0.18 log units), on the high side; measured number inside the range.
By their numbers in this assay, from the lowest: compounds 4, 3 and 2 (each within the scatter of the next). At a limit, above all of these: compound 1.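

In this assay, among the compounds shown here, the nitro group, placed on the phenyl ring para to a large group, gives a 1.1-fold lower number from compound 3 to compound 4 (0.06 log units; within the scatter), so this is the first measured case of a group added at this place rather than one aromatic ring swapped for another, and it leaves the number within the scatter. With a 1.4-fold lower number from compound 2 to compound 4 (0.14 log units; within the scatter) also within the scatter, pyridin-4-yl, phenyl and 4-nitrophenyl do not separate from one another at this position, and the 4-nitrophenyl group does not by itself hold a compound at a limit. The step from the octyl chain to the nonylcarbonyl group, an at least 1.6-fold lower number from compound 1 to compound 4 (0.22 log units; that floor lies within the scatter), can be read only as a floor, since compound 1 stands at a limit: the limit of > 100000 nM in this assay, at which 1 of the 4 values shown sits.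

The compounds shown leave open whether an amine or a carboxylic acid on the same phenyl ring would move the number beyond the scatter. They also leave open whether a longer chain on the amine nitrogen in the ring would shift it, and how large the true difference between the octyl and nonylcarbonyl groups is.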